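Amide series: outlook for compound 4

The source may hold more compounds than are shown below. What is called first, only, known or untested is meant among the compounds shown, and "the series" means these compounds.

Compound 1 `CC(C)N(Cc1cccc(OCCCCCC(=O)O)c1)C(=O)c1ccc(-c2ccncc2)cc1` gives in an ADME assay on HEK293 cells (Homo sapiens) for cytotoxicity, read by CellTiter-Glo and resazurin assay, with a stated time of 72 h; on this read-out lower numbers stand for an effect already at smaller amounts and higher numbers for an effect only at larger amounts of compound > 26000 nM, a limit of the assay rather than a number.
Compound 2 `CC(C)N(Cc1cccc(OCCCCCC(=O)O)c1)C(=O)c1ccc(-c2cc3ccccc3n2S(=O)(=O)c2ccccc2)cc1` gives in this assay > 26000 nM, likewise a limit.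
Compound 3 `CCOC(=O)CCCCCOc1cccc(CN(C(=O)c2ccc(-c3cccnc3)cc2)C(C)C)c1` gives in this assay > 26000 nM, also a limit.

Compound 3 therefore stands where every value shown stands, namely at the limit of > 26000 nM in this assay, at which 3 of the 3 values shown sit; no number separates it from compound 1 or compound 2. Compound 4 `CCOC(=O)CCCCCOc1cccc(CN(C(=O)c2ccc(-c3cc(OC)cc(OC)c3)cc2)C(C)C)c1` carries 3,5-dimethoxyphenyl in place of pyridin-3-yl on an aromatic carbon. Within the data shown here, no pair of measured compounds differs in one place, so no measured step guides the expectation. With every value at the limit, the expected step in this assay is a step that the limit leaves unreadable from compound 3 to compound 4, none beyond the scatter. Compound 4 is expected at 30000 nM, within 15000 nM to 80000 nM, and most likely reported again only as a limit.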

Compound 4, half-maximal effective concentration: > 26000 nM
Compound 4 gave a limit, no number; the forecaster's own chance of this, stated with the estimate: 80%; the middle value lies beyond the limit too.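

No step can be read from compound 3 to compound 4, as both values are limits: the limit of > 26000 nM in this assay, at which 4 of the 4 values shown sit.

In this assay the compounds shown leave open at what concentration any of them would give an effect.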